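Amide variation on the shared core: compound 4 expected

The compounds below may be only part of what the source reports. "The series", "measured", "known", "first", "only" and "open" are said of these compounds alone.

Compound 1 `CCn1c(C(=O)NCC#N)ccc1C(CC)(CC)c1ccc(OCCC(O)(CC)CC)c(C)c1` carries a (cyanomethyl)amino group on the carbonyl carbon. In a functional assay on Caco-2 cells (Homo sapiens) for antiproliferative activity, read by MTT assay, with a stated time of 48 h (on this read-out higher numbers stand for weaker inhibition and lower numbers for stronger inhibition), compound 1 gives only a limit, > 50000 nM. Compound 2 `C#CC(C)OC(=O)c1ccc(C(CC)(CC)c2ccc(OCCC(O)(CC)CC)c(C)c2)n1CC` bears (1-methylprop-2-yn-1-yl)oxy on that carbonyl carbon. In this assay compound 2 likewise reaches only the limit, > 50000 nM. Compound 3 `CCOc1ccc(NC(=O)c2ccc(C(CC)(CC)c3ccc(OCCC(O)(CC)CC)c(C)c3)n2CC)cc1` carries (4-ethoxyphenyl)amino. In this assay compound 3 also sits at the limit, > 50000 nM. Every measured value thus stands at the same limit (the limit of > 50000 nM in this assay, at which 3 of the 3 values shown sit), so the steps a step that the two limits leave unreadable from compound 1 to compound 2, a step that the two limits leave unreadable from compound 1 to compound 3 and a step that the two limits leave unreadable from compound 2 to compound 3 cannot be sized, and compound 3 stands nowhere distinguishable from compounds 1 and 2.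

Compound 4 `CCn1c(C(=O)N(C)CCO)ccc1C(CC)(CC)c1ccc(OCCC(O)(CC)CC)c(C)c1` differs from compound 3 as follows: (2-hydroxyethyl)(methyl)amino in place of (4-ethoxyphenyl)amino on a carbonyl carbon. Among the compounds with values here, no measured step bears on this change; the three exchanges on the carbonyl carbon measured so far all left the compounds at the limit (the limit of > 50000 nM in this assay, at which 3 of the 3 values shown sit). For compound 4 no movement beyond the scatter is expected, the step that the limit leaves unreadable from compound 3 to compound 4 being estimated as nil. Compound 4 is expected to give about 60000 nM, within 20000 nM to 200000 nM, and most probably again only a limit.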

Compound 4, half-maximal inhibitory concentration: 74 nM
Estimate against measurement, compound 4: 810-fold (2.91 log units) above; measured number below the stated range.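

Exchange on the carbonyl carbon is not silent in this assay: (2-hydroxyethyl)(methyl)amino gives a large drop in place of (4-ethoxyphenyl)amino (an at least 670-fold lower number from compound 3 to compound 4 (2.82 log units; beyond the scatter)), in place of (1-methylprop-2-yn-1-yl)oxy (an at least 670-fold lower number from compound 2 to compound 4 (2.82 log units; beyond the scatter)) and in place of (cyanomethyl)amino (an at least 670-fold lower number from compound 1 to compound 4 (2.82 log units; beyond the scatter)). Losing the aromatic ring cannot by itself account for this, since compound 1 also has no ring on this group and stays at a limit. These sizes are bounds only, and the steps among compounds 1, 2 and 3 cannot be read: the limit of > 50000 nM in this assay, at which 3 of the 4 values shown sit.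

The compounds shown do not separate the hydroxyl from the methyl on the nitrogen. Going by these compounds, whether (2-hydroxyethyl)amino, (2-methoxyethyl)(methyl)amino or the longer (3-hydroxypropyl)(methyl)amino would keep this activity remains open.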